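Sulfanyl to sulfonyl exchange on a growth-inhibition series

The source may hold more compounds than are shown below. What is called first, only, known or untested is meant among the compounds shown, and "the series" means these compounds.

The three measured compounds share a read-out in a functional assay on DU-145 cells (Homo sapiens) for inhibition, read by trypan blue exclusion, with a stated time of 96 h; on this read-out lower numbers stand for stronger inhibition of growth and higher numbers for weaker inhibition of growth. Compound 1 `Cc1ccc(S/C(=C/c2ccc(N(C)C)cc2)C(=O)c2ccc(Cl)cc2)cc1` reaches only a limit there, > 100000 nM. Compound 2 `Cc1ccc(S(=O)(=O)/C(=C/c2ccc(N(C)C)cc2)C(=O)c2ccc(Cl)cc2)cc1` likewise gives a limit, > 100000 nM. The pair differ by (4-methylphenyl)sulfonyl in place of (4-methylphenyl)sulfanyl on a double-bonded chain carbon bound to a carbonyl carbon and a double-bonded chain carbon, and the resulting step that the two limits leave unreadable from compound 1 to compound 2 cannot be sized, since both values rest at the limit of > 100000 nM in this assay, at which 2 of the 3 values shown sit. Among the measured compounds shown here, compound 3 `CCOc1ccc(/C=C(/Sc2ccc(C)cc2)C(=O)c2ccc(Br)cc2)cc1OC` is the one member with a read number, 50000 nM in this assay. How its core differs from that of compound 1 is not broken down here.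

Compound 4 `CCOc1ccc(/C=C(\C(=O)c2ccc(Br)cc2)S(=O)(=O)c2ccc(C)cc2)cc1OC` is not yet measured; it stands to compound 3 as compound 2 stands to compound 1, through ((4-methylphenyl)sulfonyl in place of (4-methylphenyl)sulfanyl on a double-bonded chain carbon bound to a carbonyl carbon and a double-bonded chain carbon), the same change at the same place. The earlier step being unreadable, the expectation for compound 4 leans on compound 3 and its 50000 nM, with a wide band. The step from compound 3 to compound 4 in this assay is estimated as a 1.4-fold higher number from compound 3 to compound 4 (0.15 log units; within the scatter). For compound 4 the expected value is 70000 nM, between 20000 nM and 200000 nM, with a real chance that only a limit is returned.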

Compound 4, concentration for 50% growth inhibition: 1000 nM
The estimate for compound 4 lay 70-fold (1.85 log units) above the measured number, outside the stated range (below it).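

In this assay, (4-methylphenyl)sulfonyl in place of (4-methylphenyl)sulfanyl on a double-bonded chain carbon bound to a carbonyl carbon and a double-bonded chain carbon gives a 50-fold lower number from compound 3 to compound 4 (1.70 log units; beyond the scatter), a large step on this one core. The same exchange on the core of compound 1 cannot be read, since compound 1 and compound 2 both return only a limit: the limit of > 100000 nM in this assay, at which 2 of the 4 values shown sit. The large step is therefore established for a single pair, and the unreadable pair neither confirms nor refutes that it carries over to another core, so no general rule for the series follows.

The cores of compound 1 and compound 3 differ in more than one place, which leaves open which of those differences, if any, governs the size of the step. Also open, as far as these compounds go, is how (4-methylphenyl)sulfinyl at the same place would read, and whether a carboxylic acid elsewhere on the shared scaffold would alter the step.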